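A few compounds are considered here, and "the series" means these few. Any claim that something is new, unique, unknown or untested is made for them only; others in the source may bear on it.

Compound 1 `CS(=O)(=O)Nc1ccc2oc(-c3ccccc3)nc2c1` carries a methyl on its sulfonyl sulfur. In an ADME assay on HEK293 cells (Homo sapiens) for cytotoxicity, read by resazurin assay, with a stated time of 48 h (a higher number here means that more compound is tolerated, a lower number that less compound is tolerated), compound 1 reaches only the limit of the assay, > 100000 nM, so its place is known as a range rather than a number (the limit of > 100000 nM in this assay, at which 1 of the 2 values shown sits). Compound 2 `O=[N+]([O-])c1cc(S(=O)(=O)Nc2ccc(-c3nc4ccccc4o3)cc2)ccc1Cl` gives 85000 nM in this assay. Compound 3 `COc1ccc(Cl)cc1S(=O)(=O)Nc1ccc2oc(-c3ccccc3)nc2c1` differs from compound 1 by 5-chloro-2-methoxyphenyl in place of methyl on a sulfonyl sulfur. For the measured compounds named here, no measured pair shows a change of this kind; the expectation leans on compound 2 giving 85000 nM with an aryl on the sulfonyl sulfur. The step of an at least 1.2-fold lower number from compound 1 to compound 3 (0.09 log units; that floor lies within the scatter) is expected to be small, downward but hardly beyond the scatter. Compound 3 is expected to give about 80000 nM, within 30000 nM to 200000 nM.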

Compound 3, half-maximal cytotoxic concentration: 74000 nM
Compound 3: middle estimate off by 1.1-fold (0.03 log units), on the high side; measured number inside the range.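

In this assay, 5-chloro-2-methoxyphenyl in place of methyl on the sulfonyl sulfur gives compound 3 a measured number on the core of compound 1, but the size of the step is known only as a floor (an at least 1.3-fold lower number from compound 1 to compound 3 (0.13 log units; that floor lies within the scatter)). The full size of the change stays unfixed, since compound 1 stands at a limit: the limit of > 100000 nM in this assay, at which 1 of the 3 values shown sits.

The compounds shown leave open whether the chlorine or the methoxy group matters for this step, and how a plain phenyl would compare. Going by these compounds, how an amine or a carboxylic acid on the sulfonyl sulfur would read in this assay also remains open.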